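Ethoxycarbonyl in place of ethynyl on the shared core

The compounds below may be only part of what the source reports. "The series", "measured", "known", "first", "only" and "open" are said of these compounds alone.

- compound 1 `O=C(CCc1cccc2c1B(O)OC2)Nc1ccc(Br)cc1` gives 42000 nM in an ADME assay on WI-38 cells (Homo sapiens) for cytotoxicity, read by MTT assay, with a stated time of 72 h; a lower number here means a stronger inhibitor, a higher number a weaker inhibitor
- compound 2 `C#Cc1ccc(NC(=O)CCc2cccc3c2B(O)OC3)cc1` gives > 100000 nM in this assay, which is a limit

Compound 2 has only a limit and no number (the limit of > 100000 nM in this assay, at which 1 of the 2 values shown sits). Compound 3 `CCOC(=O)c1ccc(NC(=O)CCc2cccc3c2B(O)OC3)cc1` carries ethoxycarbonyl in place of ethynyl on an aromatic carbon. From the compounds shown here alone, in an at least 2.3-fold higher number from compound 1 to compound 2 (0.37 log units; beyond the scatter) the same place changed, and that step ends on a limit, so its full size is unknown. Compound 1 at 42000 nM shows that a group at this place can give a real number, so a modest move to a lower number in this assay is expected, though a change within the scatter would be no surprise. The expected step is an at least 1.3-fold lower number from compound 2 to compound 3 (0.12 log units; that floor lies within the scatter) and the limit may well be met again. In this assay compound 3 is estimated at 75000 nM with an expected range from 30000 nM to 180000 nM in this read-out.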

Compound 3, half-maximal inhibitory concentration: > 100000 nM
Compound 3 ended at the assay's limit; the forecaster's own chance of this, stated with the estimate: 45%; middle value at least 1.3-fold (0.12 log units) away from the limit.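

In this assay, ethoxycarbonyl in place of bromo on the aromatic carbon gives an at least 2.3-fold higher number from compound 1 to compound 3 (0.37 log units; beyond the scatter). Two different groups at this place, ethynyl with 2 heavy atoms and no hydrogen-bond acceptors and ethoxycarbonyl with 5 heavy atoms and 2 hydrogen-bond acceptors, have now each given a step away from bromo, so the first such step no longer stands alone. The step between compound 2 and compound 3 cannot be read, so the two groups cannot be placed in order: the limit of > 100000 nM in this assay, at which 2 of the 3 values shown sit.

From the compounds shown here alone, compound 1 remains the only one of the three with a real number, so it is open whether bromo is unusual here or whether another group, such as chloro, an amine or a carboxylic acid, would also give a real number in this assay. Going by these compounds, how far past the limit compound 2 and compound 3 truly lie also stays open.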